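A few compounds are considered here, and "the series" means these few. Any claim that something is new, unique, unknown or untested is made for them only; others in the source may bear on it.

Measured so far in an ADME assay on microsomes from liver (Rattus norvegicus) for metabolic stability; on this read-out higher numbers stand for fast clearance and lower numbers for slow clearance:

- compound 1 `CNc1nc(NC2(C#N)CCCCC2)nc(-n2cncn2)n1` gives 52 mL/min/kg
- compound 2 `CNc1nc(NC2(C#N)CCCCC2)nc(-n2ccnc2)n1` gives 52 mL/min/kg
- compound 3 `CNc1nc(NC2(C#N)CCCCC2)nc(N(C)C)n1` gives 276 mL/min/kg

Compound 3 has the highest of the three numbers in this assay, so it stands at the fast-clearance end of this small set. The next compound to read is compound 4 `CNc1nc(NC2(C#N)CCCCC2)nc(N2CCCC2)n1`, which carries pyrrolidin-1-yl in place of dimethylamino on an aromatic carbon.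

Three measured steps vary this same position. The swap between the two non-saturated groups shows no change at the digits printed from compound 1 to compound 2 (within the scatter). Dimethylamino in place of 1H-1,2,4-triazol-1-yl shows a 5.3-fold higher number from compound 1 to compound 3 (0.72 log units; beyond the scatter), and dimethylamino in place of 1H-imidazol-1-yl shows a 5.3-fold higher number from compound 2 to compound 3 (0.72 log units; beyond the scatter). These steps are modest, and both of the larger ones end at dimethylamino. Among the measured compounds shown here, no measured step exchanges dimethylamino for another group that is also not an aromatic ring, so the data give no direct size for this change. The expectation therefore starts from compound 3 at 276 mL/min/kg and stays close to it.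

The estimated change is a 1.1-fold lower number from compound 3 to compound 4 (0.04 log units; within the scatter), which means no step beyond the scatter is expected. For compound 4 the expected value is 250 mL/min/kg, with an estimated range from 120 mL/min/kg to 500 mL/min/kg.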

Compound 4, clearance: > 276 mL/min/kg
Compound 4: a limit, no number (the forecaster's own chance of this, stated with the estimate: 5%); middle value at least 1.1-fold (0.04 log units) away from the limit.
By their numbers in this assay, from the lowest: compounds 1 and 2 (each within the scatter of the next); then compound 3.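

In this assay compound 4 gives > 276 mL/min/kg, which is a limit of the assay and not a number. Even so, pyrrolidin-1-yl on this aromatic carbon gives an at least 5.3-fold higher number from compound 2 to compound 4 (0.72 log units; beyond the scatter) and an at least 5.3-fold higher number from compound 1 to compound 4 (0.72 log units; beyond the scatter), so the high end of the set no longer rests on dimethylamino alone: both non-aromatic groups shown, in compounds 3 and 4, stand well apart from the aromatic triazolyl and imidazolyl groups of compounds 1 and 2, and no compound shown goes against this. Pyrrolidin-1-yl in place of dimethylamino gives a number no lower from compound 3 to compound 4 (the limit leaves the size open), so tying the two substituents of the amine into a ring has no readable size here, and the comparison rests on this value: the limit of > 276 mL/min/kg in this assay, at which 1 of the 4 values shown sits.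

From the compounds shown here alone, it stays open whether a non-aromatic ring with a second hetero atom, such as morpholin-4-yl, would sit with compounds 3 and 4 or with compounds 1 and 2, and whether a third aromatic ring, such as pyrazol-1-yl, would match the two seen so far. Going by these compounds, the methylamino group and the group of 9 heavy atoms also stay constant throughout, so how this position behaves with another amine in their place remains unknown.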